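Removing the bromo group: expectation for compound 3

The source may hold more compounds than are shown below. What is called first, only, known or untested is meant among the compounds shown, and "the series" means these compounds.

Among the measured compounds shown here, compound 2 `O=C(Nc1ccc(Oc2ccnc3[nH]ccc23)cc1)c1nn(-c2ccc(Br)cc2)ccc1=O` gives 8040 nM in a functional assay on PC-3 cells (Homo sapiens) for cytotoxicity, read by MTT assay, with a stated time of 72 h (on this read-out lower numbers stand for stronger inhibition and higher numbers for weaker inhibition), the lowest of the two numbers so far, while compound 1 `O=C(Nc1ccc(Oc2ccnc3[nH]ccc23)cc1)c1nn(-c2ccc(Cl)cc2)ccc1=O` gives 32400 nM. For the measured compounds named here, the single measured step, a 4.0-fold lower number from compound 1 to compound 2 (0.61 log units; beyond the scatter), is the only reference. Compound 3 `O=C(Nc1ccc(Oc2ccnc3[nH]ccc23)cc1)c1nn(-c2ccccc2)ccc1=O` differs from compound 2 by hydrogen in place of bromo on an aromatic carbon, read one bond further out as 4-bromophenyl to phenyl. Because the larger halogen lowered the number in a 4.0-fold lower number from compound 1 to compound 2 (0.61 log units; beyond the scatter), dropping the halogen is expected to raise the number modestly in this assay. For compound 3 the expected value is 24000 nM, estimated between 8000 nM and 70000 nM. The expected step is a 3.0-fold higher number from compound 2 to compound 3 (0.47 log units; beyond the scatter).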

Compound 3, half-maximal inhibitory concentration: 15000 nM
Compound 3: the middle estimate sits 1.6-fold (0.20 log units) above what was measured; the range from low to high includes it.
By their numbers in this assay, from the lowest: compounds 2 and 3 (each within the scatter of the next); then compound 1.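

In this assay hydrogen in place of bromo on this aromatic carbon gives a 1.9-fold higher number from compound 2 to compound 3 (0.27 log units; within the scatter) and so does not separate the two groups at this position. Hydrogen in place of chloro gives a 2.2-fold lower number from compound 1 to compound 3 (0.33 log units; beyond the scatter) and leaves chloro as the group that stands apart, so the higher number here does not follow halogen as such. Open, from the compounds shown here alone, is whether an amine, a methoxy group or a carboxylic acid at this place would move the number beyond the scatter around compound 3. Nothing available explains why chloro stands apart from bromo and hydrogen.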